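Pyridin-3-yl in place of thiophen-2-yl

A few compounds are considered here, and "the series" means these few. Any claim that something is new, unique, unknown or untested is made for them only; others in the source may bear on it.

Going by the values given here, in a functional assay on U-937 cells (Homo sapiens) for antiproliferative activity, read by MTT assay, with a stated time of 72 h (a lower number here means a stronger inhibitor, a higher number a weaker inhibitor), compound 2 (`O=C(CCCCCCc1nc(-c2cccs2)no1)NO`) gives 320 nM and holds the lowest of the two numbers so far, while compound 1 (`O=C(CCCCCCc1nc(-c2ccc(F)cc2)no1)NO`) gives 1930 nM in the same read-out. Compound 3 (`O=C(CCCCCCc1nc(-c2cccnc2)no1)NO`) carries pyridin-3-yl in place of thiophen-2-yl on an aromatic carbon, at the ring carbon between two ring nitrogen atoms. Among the compounds with values here, only one measured step bears on this place: the swap of 4-fluorophenyl for thiophen-2-yl gave a 6.0-fold lower number from compound 1 to compound 2 (0.78 log units; beyond the scatter) and counts as modest. Pyridin-3-yl is a six-membered aromatic ring, as is the 4-fluorophenyl of compound 1 at 1930 nM in this comparison. A move to a higher number in this assay is therefore expected, smaller than that measured step. An estimated 2.3-fold higher number from compound 2 to compound 3 (0.37 log units; beyond the scatter) is the working figure. For compound 3 the expected value is 750 nM with a range of 280 nM to 2000 nM for now.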

Compound 3, half-maximal inhibitory concentration: 350 nM
Compound 3: the middle estimate sits 2.1-fold (0.33 log units) above what was measured; the range from low to high includes it.
By their numbers in this assay, from the lowest: compounds 2 and 3 (each within the scatter of the next); then compound 1.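

In this assay, the change at this position gives a 1.1-fold higher number from compound 2 to compound 3 (0.04 log units; within the scatter), so thiophen-2-yl and pyridin-3-yl are not told apart here, despite the different ring size and hetero atom. Ring size alone therefore does not set the number: 4-fluorophenyl and pyridin-3-yl are both six-membered aromatic rings, yet the change between them gives a 5.5-fold lower number from compound 1 to compound 3 (0.74 log units; beyond the scatter) in this assay. No measured evidence on the origin of these differences is available for this series.

Plain phenyl at this position would show whether the gap to compound 1 belongs to the fluorine or to the ring itself. Going by these compounds, how the number responds to an aminomethyl group or a carboxylic acid on the ring, or to a longer chain in the core, remains open.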